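A few compounds are considered here, and "the series" means these few. Any claim that something is new, unique, unknown or untested is made for them only; others in the source may bear on it.

Measured so far:
- compound 1 `O=C1/C(=C/c2ccc(Cl)cc2)NS(=O)(=O)c2ccccc21`: 4350 nM in an assay for inhibition of Intestinal-type alkaline phosphatase (Homo sapiens), read by spectrophotometry, with stated times of 10 min and 20 min; a lower number here means a stronger inhibitor, a higher number a weaker inhibitor
- compound 2 `O=C1/C(=C/c2ccc(F)cc2)NS(=O)(=O)c2ccccc21`: 3060 nM in this assay

Compound 2 and compound 1 sit within the scatter of each other in this assay; the one step between them, a 1.4-fold lower number from compound 1 to compound 2 (0.15 log units; within the scatter), does not separate them, so compound 2 stands apart from nothing on the numbers shown.

Compound 3 `Cc1ccccc1/C=C1\NS(=O)(=O)c2ccccc2C1=O` is not yet measured in this assay. It differs from compound 2 in one place: 2-methylphenyl in place of 4-fluorophenyl on a double-bonded chain carbon bound to a double-bonded ring carbon. Within the data shown here, no measured step covers this change. Among the measured compounds shown here, the only step in hand, a 1.4-fold lower number from compound 1 to compound 2 (0.15 log units; within the scatter), swaps one halogen for another at the same ring and stays within the scatter; it says only that a small change on this ring left the number where it was. For the measured compounds named here, a methyl-bearing ring in a different substitution pattern is a change of another kind, and the series gives no step of that kind to rest on.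

With no evidence either way, the expectation for compound 3 is a number close to that of compound 2, and the step of a 1.1-fold higher number from compound 2 to compound 3 (0.06 log units; within the scatter) is estimated to stay within the scatter. The estimate for compound 3 in this assay is 3500 nM, with a wide range from 1200 nM to 11000 nM to allow for the untested change.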

Compound 3, half-maximal inhibitory concentration: 3750 nM
Compound 3: the middle estimate sits 1.1-fold (0.03 log units) below what was measured; the range from low to high includes it.
By their numbers in this assay, from the lowest: compounds 2, 3 and 1 (each within the scatter of the next).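

In this assay the change to 2-methylphenyl from 4-fluorophenyl gives a 1.2-fold higher number from compound 2 to compound 3 (0.09 log units; within the scatter) and the change to 2-methylphenyl from 4-chlorophenyl gives a 1.2-fold lower number from compound 1 to compound 3 (0.06 log units; within the scatter) and so neither step separates compound 3 from its neighbours. The earlier pair showed only one halogen exchanged for another on the same ring, whereas these steps show that a ring bearing methyl and no halogen, with its substituent in a different pattern, also leaves the number within the scatter at this place on the double-bonded chain carbon bound to a double-bonded ring carbon. No measurement in hand accounts for the three aromatic groups reading alike.

All the groups compared at this place are substituted phenyl rings carrying a single halogen or methyl, so no change here has yet given a step beyond the scatter. Open, from the compounds shown here alone, is whether a carboxylic acid or an amine on the ring, or a longer chain in place of the ring, would move the number in this assay or leave it where these three compounds sit.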